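This account rests on a few compounds, and the source may have more. Where it says the series, first, only, none or still open, it means among the compounds named here.

Measured in a functional assay on MCF7 cells (Homo sapiens) for inhibition, read by sulforhodamine B assay, with a stated time of 48 h; a higher number here means a weaker inhibitor of growth, a lower number a stronger inhibitor of growth: compound 1 `COc1ccc(-c2cc(/C=C/C(=O)c3ccc(N)cc3)[nH]n2)cc1`, 780 nM; compound 2 `COc1cc(-c2cc(/C=C/C(=O)c3ccc(Cl)c(Cl)c3)[nH]n2)cc(OC)c1OC`, 1800 nM; compound 3 `COc1ccc(C(=O)/C=C/c2cc(-c3cc(OC)c(OC)c(OC)c3)n[nH]2)cc1`, 1150 nM.

Compound 1 gives the lowest of the three numbers; compound 3 sits within the scatter of it and compound 2 beyond it. Compound 4 `COc1ccc(-c2cc(/C=C/C(=O)c3ccc(N)cc3)[nH]n2)cc1OC` differs from compound 1 by methoxy in place of hydrogen on an aromatic carbon. Going by the values given here, no measured step touches that part of the molecule: the one single-point step, a 1.6-fold lower number from compound 2 to compound 3 (0.19 log units; within the scatter), alters the group on the carbonyl carbon and is within the scatter. Compounds 1 and 3 differ in the methoxy count on the shared core but also in a second place, so their gap gives no clean reading. The step of a 1.2-fold higher number from compound 1 to compound 4 (0.06 log units; within the scatter) in this assay is therefore expected to be none beyond the scatter. Compound 4 is estimated at 900 nM, range 400 nM to 2000 nM.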

Compound 4, concentration for 50% growth inhibition: 2280 nM
Compound 4: the middle estimate sits 2.5-fold (0.40 log units) below what was measured; measured number outside the range, above it.
By their numbers in this assay, from the lowest: compounds 1, 3, 2 and 4 (each within the scatter of the next, the first and the last beyond it).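

Methoxy in place of hydrogen, on an aromatic carbon ortho to a methoxy group, is not a silent change: in this assay it gives a 2.9-fold higher number from compound 1 to compound 4 (0.47 log units; beyond the scatter) and so shows that this position responds to substitution. Going by these compounds alone, the only earlier step, at the group on the carbonyl carbon, stayed within the scatter. No evidence in hand bears on the reason for this step.

Going by these compounds, whether the rise belongs to methoxy itself or to any group at this carbon remains open. Hydroxy, fluorine or a longer ethoxy chain there would help separate the two.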